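One added methyl on the piperazine of compound 3

This account rests on a few compounds, and the source may have more. Where it says the series, first, only, none or still open, it means among the compounds named here.

Of the compounds shown here, three sharing one core have been measured in a functional assay on U-937 cells (Homo sapiens) for cytotoxicity, read by MTT assay, with a stated time of 3 days; on this read-out lower numbers stand for stronger inhibition and higher numbers for weaker inhibition. Compound 1 `CNc1nc(SCc2nc3ccccc3[nH]2)nc(-c2ccccc2)c1C#N`, carrying methylamino, gives 19.2 nM. Compound 2 `N#Cc1c(Nc2nccs2)nc(SCc2nc3ccccc3[nH]2)nc1-c1ccccc1`, carrying (1,3-thiazol-2-yl)amino, gives 3.8 nM. Compound 3 `N#Cc1c(-c2ccccc2)nc(SCc2nc3ccccc3[nH]2)nc1N1CCNCC1`, carrying piperazin-1-yl, gives 5.81 nM. On these numbers, the piperazine compound cannot be told apart from the thiazole compound, with a 1.5-fold higher number from compound 2 to compound 3 (0.18 log units; within the scatter). It does stand clear of the methylamino compound, with a 3.3-fold lower number from compound 1 to compound 3 (0.52 log units; beyond the scatter).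

The next candidate is compound 4 `CN1CCN(c2nc(SCc3nc4ccccc4[nH]3)nc(-c3ccccc3)c2C#N)CC1`, and its difference is methyl in place of hydrogen on an amine nitrogen in a ring, turning piperazin-1-yl into 4-methylpiperazin-1-yl.

Within the data shown here, no measured step makes this exact change. The closest evidence comes from exchanging the whole group on an aromatic carbon, which gave modest steps, a 5.1-fold lower number from compound 1 to compound 2 (0.70 log units; beyond the scatter) and the piperazine step above, or none beyond the scatter, as in a 1.5-fold higher number from compound 2 to compound 3 (0.18 log units; within the scatter). A single added methyl is a far smaller edit than those exchanges, so no step beyond the scatter is expected in this assay. For compound 4 the estimated value is 6 nM, with an expected range from 2.5 nM to 15 nM. This estimate amounts to a 1.0-fold higher number from compound 3 to compound 4 (0.01 log units; within the scatter).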

Compound 4, half-maximal inhibitory concentration: 6.75 nM
Compound 4: middle estimate off by 1.1-fold (0.05 log units), on the low side; the measured number falls inside the stated range.
By their numbers in this assay, from the lowest: compounds 2, 3 and 4 (each within the scatter of the next); then compound 1.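

In this assay, putting a methyl on the amine nitrogen in the ring of the piperazine gives a step that stays within the scatter (a 1.2-fold higher number from compound 3 to compound 4 (0.07 log units; within the scatter)), so this nitrogen can carry the one added carbon without a difference these numbers can resolve. The 4-methylpiperazin-1-yl compound also cannot be told apart from the compound carrying (1,3-thiazol-2-yl)amino (a 1.8-fold higher number from compound 2 to compound 4 (0.25 log units; within the scatter)), yet it stands clear of the compound carrying methylamino (a 2.8-fold lower number from compound 1 to compound 4 (0.45 log units; beyond the scatter)), so the separation already seen with piperazin-1-yl is still there once the methyl is added. Nothing available gives a reason for this result.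

The compounds shown leave open how much more this nitrogen can carry, for instance an ethyl, an acetyl or a longer chain ending in an amine or a carboxylic acid, since a single methyl says little about groups of that size. From the compounds shown here alone, all of these numbers also come from this assay, so it remains open whether the methyl would be just as hard to detect on any other kind of cell.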